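This account rests on a few compounds, and the source may have more. Where it says the series, first, only, none or still open, it means among the compounds named here.

Compound 1, `O=S(=O)(Nc1ccc(-c2nc3ccccc3o2)cc1)c1ccccc1O`: in an assay on isolated protein for inhibition of malate dehydrogenase, mitochondrial (Sus scrofa), with stated times of 45 min and 30 min (a higher number here means a weaker inhibitor, a lower number a stronger inhibitor), compound 1 gives > 63000 nM, which is a limit of the assay rather than a number.
Compound 2, `COc1ccccc1S(=O)(=O)Nc1ccc(-c2nc3ccccc3o2)cc1`: in this assay compound 2 gives > 63000 nM, again only a limit.
Compound 3, `COc1cccc(S(=O)(=O)Nc2ccc(-c3nc4ccccc4o3)cc2)c1`: in this assay compound 3 gives > 63000 nM, also a limit.

Compound 3 therefore cannot be placed among its neighbours on the numbers shown: all three values sit at the limit of > 63000 nM in this assay, at which 3 of the 3 values shown sit, and none of them is a real inhibitory concentration. The steps between them are unreadable for the same reason: a step that the two limits leave unreadable from compound 1 to compound 2, a step that the two limits leave unreadable from compound 1 to compound 3 and a step that the two limits leave unreadable from compound 2 to compound 3 all run from one limit to another.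

Compound 4, `Cc1ccc(S(=O)(=O)Nc2ccc(-c3nc4ccccc4o3)cc2)cc1`, is the next compound to be tested in this assay. It differs from compound 3 in one place: 4-methylphenyl in place of 3-methoxyphenyl on a sulfonyl sulfur. Of the measured steps, those ending at compound 3 are the ones that bear on this change, and neither gives a size, so there is no measured ground for expecting a change beyond the scatter in either direction. The estimate for compound 4 is 100000 nM, with a range from 30000 nM to 400000 nM, which means an expected step that the limit leaves unreadable from compound 3 to compound 4; most likely the assay will again report only a limit.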

Compound 4, half-maximal inhibitory concentration: > 63000 nM
Compound 4 gave a limit, no number; the forecaster's own chance of this, stated with the estimate: 85%; the middle value is on the limit's open side.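

Compound 4 gives > 63000 nM in this assay, which is a limit and not a number, so its steps from compound 1, compound 2 and compound 3 cannot be read: the limit of > 63000 nM in this assay, at which 4 of the 4 values shown sit.

The compounds shown leave open whether any group on the sulfonyl sulfur can give a real inhibitory concentration in this assay, and how far these four compounds differ.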